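The source may hold more compounds than are shown below. What is called first, only, known or untested is meant among the compounds shown, and "the series" means these compounds.

In a functional assay on NCI-H460 cells (Homo sapiens) for inhibition, read by MTT assay, with a stated time of 72 h (a lower number here means a stronger inhibitor, a higher number a weaker inhibitor), three compounds sharing one core have been measured so far. Compound 1 `O=C1Nc2ccccc2/C1=C\C(=O)c1cccc(Cl)c1` has chloro on an aromatic carbon and reads 9800 nM as its value. Compound 2 `CCC(=O)Nc1cccc(C(=O)/C=C2/C(=O)Nc3ccccc32)c1` has propanoylamino in that place and reads 10300 nM as its value. Compound 3 `CC(C)C(=O)Nc1cccc(C(=O)/C=C2/C(=O)Nc3ccccc32)c1` has (isopropylcarbonyl)amino there and reads 9700 nM so it stands level with both others, within the usual scatter.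

Compound 4 `CC(=O)Nc1cccc(C(=O)/C=C2/C(=O)Nc3ccccc32)c1` is still unmeasured. Compared with compound 3 it has methyl in place of isopropyl on a carbonyl carbon so that (isopropylcarbonyl)amino becomes acetamido. The closest measured change is a 1.1-fold lower number from compound 2 to compound 3 (0.03 log units; within the scatter) for methyl in place of hydrogen on the chain. Replacing chloro with these groups gave a 1.1-fold higher number from compound 1 to compound 2 (0.02 log units; within the scatter) and a 1.0-fold lower number from compound 1 to compound 3 (0.00 log units; within the scatter) as the other two steps. None of the three leaves the scatter, so a shift beyond it is not expected here. The estimated change is a 1.0-fold higher number from compound 3 to compound 4 (0.01 log units; within the scatter) with no clear direction. For compound 4 the expected value is 10000 nM with an estimated range from 5500 nM to 18000 nM as its upper end.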

Compound 4, half-maximal inhibitory concentration: 12300 nM
Compound 4: the middle estimate sits 1.2-fold (0.09 log units) below what was measured, within the range that was stated.
By their numbers in this assay, from the lowest: compounds 3, 1, 2 and 4 (each within the scatter of the next).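

Compound 4 brings in the smallest acyl group shown: methyl (1 heavy atom) in place of isopropyl (3 heavy atoms) on a carbonyl carbon gives a 1.3-fold higher number from compound 3 to compound 4 (0.10 log units; within the scatter) in this assay, and hydrogen in place of methyl on the chain gives a 1.2-fold higher number from compound 2 to compound 4 (0.08 log units; within the scatter) as the matching step. Acetamido in place of chloro on an aromatic carbon gives a 1.3-fold higher number from compound 1 to compound 4 (0.10 log units; within the scatter) and stays within the scatter like the other steps, so chloro and all three amides read level, and changing the chain on the carbonyl carbon does not separate them. Nothing at hand explains this flat reading.

The compounds shown leave open whether a group of another kind here, such as a free amine or a carboxylic acid, would move the number beyond the scatter. They also leave open whether a much longer chain on the carbonyl carbon, or a change on the shared core, would do so.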